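From Isobutoxy to Methoxy: Compound 2 to Compound 4

A few compounds are considered here, and "the series" means these few. Any claim that something is new, unique, unknown or untested is made for them only; others in the source may bear on it.

Of the compounds shown here, three have been measured in a functional assay on A549 cells (Homo sapiens) for antiproliferative activity, read by sulforhodamine B assay, with a stated time of 3 days; on this read-out lower numbers stand for an effect already at smaller amounts and higher numbers for an effect only at larger amounts of compound. Compound 1 `CCCC1(CC=C(C)C)C(=O)C(C(=O)/C=C/c2ccccc2)=C(O)C(CCC)(CCC)C1=O` gives 7.1 uM, compound 3 `COC1=C(CC(C)C)C(=O)/C(=C(O)/C=C/c2ccccc2)C(=O)C1(CC(C)C)CC(C)C` gives 4.4 uM, and compound 2 `CCCC1=C(OCC(C)C)C(CCC)(CCC)C(=O)/C(=C(O)\C=C\c2ccccc2)C1=O` gives 1.7 uM, the lowest of the three numbers, beyond the scatter from both compound 3 and compound 1. Compound 4 `CCCC1=C(OC)C(CCC)(CCC)C(=O)/C(=C(O)\C=C\c2ccccc2)C1=O` has not yet been measured. It differs from compound 2 in one place: hydrogen in place of isopropyl on a saturated chain carbon bound to an oxygen on an unsaturated carbon. For the measured compounds named here, no step between measured compounds that differ in one place is available, so the expectation rests on the numbers themselves. Compound 3, which carries a methoxy on its core, gives 4.4 uM. On that basis the account expects a modest step toward a higher number, a 1.5-fold higher number from compound 2 to compound 4 (0.17 log units; within the scatter), near the edge of the scatter. Compound 4 is estimated at 2.5 uM, with a range from 1 uM to 6.5 uM.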

Compound 4, concentration for half-maximal effect: 3.6 uM
Compound 4: the middle estimate sits 1.4-fold (0.16 log units) below what was measured; measured number inside the range.
By their numbers in this assay, from the lowest: compound 2; then compounds 4, 3 and 1 (each within the scatter of the next).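

In this assay, for the compounds shown here, the change from isobutoxy to methoxy gives the first direct reading at this position, a step of a 2.1-fold higher number from compound 2 to compound 4 (0.33 log units; beyond the scatter) with everything else on the core held constant. The isopropyl on the saturated chain carbon bound to an oxygen on an unsaturated carbon therefore makes a measurable, though modest, difference to the number. Nothing available explains this step.

With only these two groups compared here, the compounds shown leave open how the number changes along the series. An ethoxy, a longer chain such as hexyloxy, or a chain ending in an amine could each read differently at this oxygen.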